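Benzyl ether variation on the chloro benzimidazole urea

The source may report more compounds than this note shows. Statements on the series, on what has been measured and on what is new or still open speak of the compounds shown alone.

Two compounds of this series carry a number in a functional assay on HT-29 cells (Homo sapiens) for inhibition, read by MTT assay, with a stated time of 48 h; a lower number here means a stronger inhibitor, a higher number a weaker inhibitor. Compound 1 `Cc1ccc(COc2ccc(C(=O)NC(=O)Nc3ccc(C)c(-c4nc5ccccc5[nH]4)c3)cc2)cc1` gives 5110 nM in this assay. Among the measured compounds shown here, compound 2 `O=C(NC(=O)c1ccc(OCc2ccccc2F)cc1)Nc1ccc(Cl)c(-c2nc3ccccc3[nH]2)c1` gives 590 nM in this assay, the lower of the two numbers; compound 1, the only other measured compound, stands at a higher number, and that gap lies beyond the scatter. For the measured compounds named here, compound 1 and compound 2 differ in two places at once, so no single step between them is laid out.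

Compound 3 `Cc1ccc(COc2ccc(C(=O)NC(=O)Nc3ccc(Cl)c(-c4nc5ccccc5[nH]4)c3)cc2)cc1` has not yet been measured in this assay. It differs from compound 2 in one place: 4-methylphenyl in place of 2-fluorophenyl on a saturated chain carbon bound to an oxygen on an aromatic ring. With this change compound 3 shares the (4-methylbenzyl)oxy group of compound 1 and the chloro-bearing core of compound 2. Going by the values given here, there is no measured pair that isolates this change. The expected step from compound 2 to compound 3 is a 2.5-fold higher number from compound 2 to compound 3 (0.41 log units; beyond the scatter), towards a weaker inhibitor, since compound 1 with the same benzyl group gives 5110 nM. Compound 3 is estimated at 1500 nM in this assay, with a range from 500 nM to 5000 nM.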

Compound 3, half-maximal inhibitory concentration: 2950 nM
Compound 3: the middle estimate sits 2.0-fold (0.29 log units) below what was measured, and the stated range covers the measured number.
By their numbers in this assay, from the lowest: compound 2; then compounds 3 and 1 (each within the scatter of the next).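

In this assay the swap of 2-fluorophenyl for 4-methylphenyl on a saturated chain carbon bound to an oxygen on an aromatic ring now has its own measured pair, and the step of a 5.0-fold higher number from compound 2 to compound 3 (0.70 log units; beyond the scatter) puts this group change beyond the scatter on the chloro-bearing core. The second pair, chloro in place of methyl on an aromatic carbon with the (4-methylbenzyl)oxy group held constant, gives the step of a 1.7-fold lower number from compound 1 to compound 3 (0.24 log units; within the scatter) and so shows no change that can be told from the scatter at this place. No measurement in hand accounts for either step.

Among the compounds shown here, the single benzyl pair changes both the substituent and where it sits, so it leaves open whether losing the 2-fluoro group or gaining the 4-methyl group carries the step, a question that plain benzyl, 4-fluorobenzyl or 2-methylbenzyl on the chloro-bearing core would separate. Going by these compounds, whether chloro and methyl also read alike when the 2-fluorobenzyl group is present remains open too.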